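Methyl in place of furan-2-yl on the shared core

The source may hold more compounds than are shown below. What is called first, only, known or untested is meant among the compounds shown, and "the series" means these compounds.

Within the data shown here, in a functional assay on K562-TAX cells (Homo sapiens), read by MTT assay, with a stated time of 3 days (on this read-out lower numbers stand for stronger inhibition and higher numbers for weaker inhibition), compound 2 `c1coc(-c2ncnc3[nH]cc(Sc4cccs4)c23)c1` stands at 18900 nM as one of only two numbers, and compound 1 `c1csc(Sc2c[nH]c3ncnc(-c4cccs4)c23)c1` at 21700 nM lies within the scatter of it. Among the measured compounds shown here, the single measured step is a 1.1-fold lower number from compound 1 to compound 2 (0.06 log units; within the scatter) for furan-2-yl in place of thiophen-2-yl on an aromatic carbon. That step exchanges one five-membered aromatic ring for another. Compound 3 `Cc1ncnc2[nH]cc(Sc3cccs3)c12` instead carries methyl in place of furan-2-yl on an aromatic carbon, so the ring is lost: methyl in place of furan-2-yl on an aromatic carbon. For the measured compounds named here, no measured compound shows what losing it does, so the step from compound 1 offers only a weak guide. A small move toward a higher number is expected, and the estimated change is a 1.5-fold higher number from compound 2 to compound 3 (0.17 log units; within the scatter) in this assay with wide uncertainty. Compound 3 is thus estimated at 28000 nM with an expected range of 11000 nM to 70000 nM in this read-out.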

Compound 3, half-maximal inhibitory concentration: > 50000 nM
Compound 3: no number, only a limit; the forecaster's own chance of this, stated with the estimate: 20%; middle value at least 1.7-fold (0.25 log units) from the limit.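

In this assay, among these compounds, this position on the shared core had so far held only five-membered aromatic rings, and exchanging one for the other stayed within the scatter; replacing the ring with methyl moves beyond the scatter, giving an at least 2.6-fold higher number from compound 2 to compound 3 (0.42 log units; beyond the scatter) and, from the thiophen-2-yl ring, an at least 2.3-fold higher number from compound 1 to compound 3 (0.36 log units; beyond the scatter). The reading for compound 3 is a limit and not a number: the limit of > 50000 nM in this assay, at which 1 of the 3 values shown sits. Among these three compounds, then, the two carrying an aromatic ring at this position give the lower numbers, and the one carrying methyl does not.

The compounds shown do not tell whether a phenyl ring, a saturated ring such as cyclohexyl or a longer chain such as butyl would sit with compound 1 and compound 2 or with compound 3. Going by these compounds, how far the true number of compound 3 lies from its limit also stays open.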